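The source may hold more compounds than are shown below. What is called first, only, known or untested is meant among the compounds shown, and "the series" means these compounds.

In a functional assay on KBVIN cells (Homo sapiens) for antiproliferative activity, read by sulforhodamine B assay, with a stated time of 3 days (a lower number here means that less compound is needed, a higher number that more compound is needed for the effect), compound 3 `CCC1=C(O)c2c(oc(-c3ccc(OC)c(C)c3)cc2=O)C(CC)(CC)C1=O` stands lowest of the three measured compounds at 0.1 uM. Compound 2 `CCC1=C(O)c2c(oc(-c3ccc(OC)cc3C)cc2=O)C(CC)(CC)C1=O` gives 2.62 uM and compound 1 `CCC1=C(O)c2c(oc(-c3cc(C)c(C)cc3C)cc2=O)C(CC)(CC)C1=O` gives 4.37 uM, and these two lie within the scatter of each other, with a 1.7-fold lower number from compound 1 to compound 2 (0.22 log units; within the scatter). Compound 4 `CCC1=C(O)c2c(oc(-c3cc(C)c(OC)cc3C)cc2=O)C(CC)(CC)C1=O` has not yet been measured. It differs from compound 3 by a single change, methyl in place of hydrogen on an aromatic carbon.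

Among the compounds with values here, two measured steps bear most directly on this change. One is a 26-fold lower number from compound 2 to compound 3 (1.42 log units; beyond the scatter), and the other is a 44-fold lower number from compound 1 to compound 3 (1.64 log units; beyond the scatter). Both are large, and in each the compound with the higher number carries, like compound 4, a methyl ortho to a large group. Three compounds cannot establish a pattern, but a large upward step is expected in this assay, bringing compound 4 toward the values of the other two. The rise may fall somewhat short of theirs, since compound 4 keeps the whole aryl substitution of compound 3. The expected step is a 15-fold higher number from compound 3 to compound 4 (1.18 log units; beyond the scatter). For compound 4 the estimated value is 1.5 uM, with an expected range from 0.4 uM to 5 uM.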

Compound 4, concentration for half-maximal effect: 7.58 uM
For compound 4 the middle estimate is 5.1-fold (0.70 log units) below the measured one; the measured number lies above the stated range.
By their numbers in this assay, from the lowest: compound 3; then compounds 2, 1 and 4 (each within the scatter of the next, the first and the last beyond it).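

In this assay, a methyl on the aromatic carbon ortho to a large group, meta to a methoxy group and para to a methyl group gives a 76-fold higher number from compound 3 to compound 4 (1.88 log units; beyond the scatter) and thereby removes the low number of compound 3 by itself, with the rest of its aryl substitution left in place. The methyl that compound 3 and compound 4 share does not restore that low number once this new methyl is present, as a 2.9-fold higher number from compound 2 to compound 4 (0.46 log units; beyond the scatter) shows, a modest step that goes the opposite way from the large drop seen between compound 2 and compound 3. Methoxy in place of methyl then makes no clear difference with the methyl at this position in place, since a 1.7-fold higher number from compound 1 to compound 4 (0.24 log units; within the scatter) stays within the scatter.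

Nothing shown here accounts for these steps, so their cause stays unknown. As far as these compounds go, it remains open whether only a methyl at this position has this effect or whether a fluorine, a chlorine, a hydroxyl or an ethyl group there would raise the number of compound 3 as much.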